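The source may report more compounds than this note shows. Statements on the series, on what has been measured and on what is new or still open speak of the compounds shown alone.

Compound 1 `C[C@@H](C(=O)N[C@H](C#N)CC(N)=O)N(Cc1ccc(-c2ccc(F)c(F)c2)cc1)S(C)(=O)=O`: 252 nM
Compound 2 `C[C@H](C(=O)N[C@H](C#N)CC(N)=O)N(Cc1ccc(-c2ccc(F)c(F)c2)cc1)S(C)(=O)=O`: 6300 nM
Compound 3 `CCS(=O)(=O)N(Cc1ccc(-c2cccc(F)c2)cc1)[C@@H](C)C(=O)N[C@H](C#N)CC(N)=O`: 3890 nM

All three were tested in an assay on isolated protein for inhibition of legumain (Homo sapiens), with stated times of 2 min and 60 min; a lower number here means a stronger inhibitor, a higher number a weaker inhibitor. Compound 1 gives 252 nM in this assay, the lowest of the three numbers, so it stands as the strongest inhibitor of the set. Compound 3 gives 3890 nM; the two values show a clear gap, but compound 3 differs from compound 1 in more than one place, so no single change can be read from that pair. Compound 2 is the same molecule as compound 1 apart from the configuration at one saturated chain carbon, and the step is a 25-fold higher number from compound 1 to compound 2 (1.40 log units; beyond the scatter); this large loss rests on (the fact that compounds 1 and 2 differ only in the configuration as drawn).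

Compound 4 `C[C@@H](C(=O)N[C@H](C#N)CC(N)=O)N(Cc1ccc(-c2cccc(C(F)(F)F)c2)cc1)S(C)(=O)=O` is the compound still to be measured. It differs from compound 1 by 3-(trifluoromethyl)phenyl in place of 3,4-difluorophenyl on an aromatic carbon. For the measured compounds named here, no measured step touches this ring in such a way: the one measured step concerns only the configuration at a chain carbon, and compound 3 changes two groups at once. With nothing bearing directly on the change, the expected effect is small, within or near the scatter, with no firm direction. Compound 4 is therefore expected to give about 400 nM in this assay, between 120 nM and 1400 nM. The expected step is a 1.6-fold higher number from compound 1 to compound 4 (0.20 log units; within the scatter).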

Compound 4, half-maximal inhibitory concentration: 601 nM
Compound 4: the middle estimate sits 1.5-fold (0.18 log units) below what was measured; low and high end bracket the measured number.
By their numbers in this assay, from the lowest: compound 1; then compound 4; then compounds 3 and 2 (each within the scatter of the next).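

In this assay, this is the first single change on the outer aromatic ring among the compounds shown, and replacing 3,4-difluorophenyl with 3-(trifluoromethyl)phenyl carries a real but modest cost: a 2.4-fold higher number from compound 1 to compound 4 (0.38 log units; beyond the scatter). The ring therefore accepts a larger group of the same kind, with its 10 heavy atoms against 8, and the compound remains an inhibitor, although the number does rise. This step is much smaller than the one seen on changing the configuration at the chain carbon, a 25-fold higher number from compound 1 to compound 2 (1.40 log units; beyond the scatter), yet nothing measured here explains why the ring change costs what it does.

The swap alters both the number of fluorines and the way they are attached, so these compounds do not show which of the two matters, and a 3-fluorophenyl ring on the core of compound 1 would help to separate them. Going by these compounds, it also remains open how this position would respond to a group of another kind, such as an amine, a carboxylic acid or a methoxy group, in place of the fluorinated substituents.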